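Amide to Urea: From Compound 1 Toward Compound 3

The compounds below may be only part of what the source reports. "The series", "measured", "known", "first", "only" and "open" are said of these compounds alone.

Compound 1 `COc1cc(-c2nn(-c3cccc(NC(=O)c4ccc(Cl)c(C(F)(F)F)c4)c3)cc2-c2ccncc2)ccc1Cl` in a functional assay on BT-549 cells (Homo sapiens) for inhibition, read by sulforhodamine B assay, with a stated time of 48 h (a lower number here means a stronger inhibitor of growth, a higher number a weaker inhibitor of growth), gives only a limit of the assay, > 32500 nM. Among the two numbers shown it sits at the limit of > 32500 nM in this assay, at which 1 of the 2 values shown sits. Compound 2 `O=C(Nc1cccc(-n2cc(-c3ccncc3)c(-c3ccc(Cl)c(O)c3)n2)c1)Nc1cc(C(F)(F)F)cc(C(F)(F)F)c1` gives 2120 nM in this assay, a measured number rather than a limit.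

Compound 3 `COc1cc(-c2nn(-c3cccc(NC(=O)Nc4ccc(Cl)c(C(F)(F)F)c4)c3)cc2-c2ccncc2)ccc1Cl` differs from compound 1 by (4-chloro-3-(trifluoromethyl)phenyl)amino in place of 4-chloro-3-(trifluoromethyl)phenyl on a carbonyl carbon. Going by the values given here, no measured pair isolates this change, so the direction is uncertain; a gain toward a measurable value is expected, but only a moderate one.

The step from compound 1 to compound 3 is estimated at an at least 3.2-fold lower number from compound 1 to compound 3 (0.51 log units; beyond the scatter). Compound 3 is expected to give about 10000 nM in this assay, within 2500 nM to 32500 nM.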

Compound 3, concentration for total growth inhibition: 10200 nM
Estimate against measurement, compound 3: 1.0-fold (0.01 log units) below; the range from low to high includes it.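

Going by these compounds alone, putting (4-chloro-3-(trifluoromethyl)phenyl)amino in place of 4-chloro-3-(trifluoromethyl)phenyl on the carbonyl carbon turns the amide into a urea, and this is the first pair that isolates a single change. In this assay it moves the compound from the limit to a measured value, with (an at least 3.1-fold lower number from compound 1 to compound 3 (0.50 log units; beyond the scatter)). The true size of this step cannot be fixed, because compound 1 gives only a limit: (the limit of > 32500 nM in this assay, at which 1 of the 3 values shown sits).

On these data alone, whether a carbamate oxygen or a methylene in place of the new nitrogen would do the same remains open. Compound 2 differs from compound 3 in more than one place, so it cannot show whether the step holds on other substitution patterns.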